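A few compounds are considered here, and "the series" means these few. Any claim that something is new, unique, unknown or untested is made for them only; others in the source may bear on it.

Measured so far in an ADME assay on a cell-free system (plasma, Homo sapiens) for metabolic stability; on this read-out lower numbers stand for a shorter-lived compound and higher numbers for a longer-lived compound:

- compound 1 `C[C@@H]1C(=O)N(S(C)(=O)=O)[C@H]2CCN(C(=O)OCc3ccccc3)[C@H]12`: < 0.0834 h (a limit)
- compound 2 `CNC(=O)N1C(=O)[C@@H](C)[C@@H]2[C@@H]1CCN2C(=O)OCc1ccccc1`: > 24 h (a limit)
- compound 3 `CC1CC1C(=O)N1C(=O)[C@@H](C)[C@@H]2[C@@H]1CCN2C(=O)OCc1ccccc1`: 2.6 h

Among the measured compounds shown here, compound 3, at 2.6 h, holds the only true number in this assay. The values of compound 1 and compound 2 are limits, and the number for compound 3 falls between them. The next compound is compound 4 `C[C@@H]1C(=O)N(c2nccs2)[C@H]2CCN(C(=O)OCc3ccccc3)[C@H]12`, in which 1,3-thiazol-2-yl stands in place of (2-methylcyclopropyl)carbonyl on the amide-type nitrogen in a ring: 1,3-thiazol-2-yl in place of (2-methylcyclopropyl)carbonyl on an amide-type nitrogen in a ring.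

All three measured steps concern this same nitrogen. Methylcarbamoyl in place of methylsulfonyl gave a large step, an at least 280-fold higher number from compound 1 to compound 2 (2.45 log units; beyond the scatter). (2-Methylcyclopropyl)carbonyl in place of methylsulfonyl was also large, an at least 31-fold higher number from compound 1 to compound 3 (1.49 log units; beyond the scatter). The step between the two carbonyl-linked groups was at least modest, an at least 9.2-fold lower number from compound 2 to compound 3 (0.96 log units; beyond the scatter).

So this position can move the read-out a long way, but no measured compound carries 1,3-thiazol-2-yl, and the direction is uncertain. For the measured compounds named here, compound 1, with < 0.0834 h as its limit, is the only short-lived example, and the new group is not methylsulfonyl, so a collapse seems less likely than a modest rise. The expected change is a 3.1-fold higher number from compound 3 to compound 4 (0.49 log units; beyond the scatter), an estimate with wide uncertainty. For compound 4 the estimated half-life is 8 h, with an expected range from 1.5 h to 40 h.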

Compound 4, half-life: 44 h
The estimate for compound 4 lay 5.5-fold (0.74 log units) below the measured number; measured number outside the range, above it.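

In this assay, 1,3-thiazol-2-yl on the amide-type nitrogen gives a 17-fold higher number from compound 3 to compound 4 (1.23 log units; beyond the scatter), and against methylsulfonyl it gives an at least 520-fold higher number from compound 1 to compound 4 (2.72 log units; beyond the scatter). Among the compounds shown here, all three earlier groups on this nitrogen were joined through a carbonyl or a sulfonyl, so compound 4 shows that a five-membered aromatic ring, attached directly, can also sit here and give a long half-life; it also gives the first true number at the long-lived end of the series, where only a limit stood before. The step from compound 2 to compound 4 cannot be read, because compound 2 gives only a limit and not a number: the limit of > 24 h in this assay, at which 1 of the 4 values shown sits.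

As far as these compounds go, with a single aromatic ring on this nitrogen, it stays open whether the long half-life belongs to aromatic rings in general or to this ring with its sulfur and nitrogen. A phenyl or a 1,3-oxazol-2-yl group at the same place, on the same core, would help separate these possibilities, and would show how far the result reaches beyond compound 4.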